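A few compounds are considered here, and "the series" means these few. Any claim that something is new, unique, unknown or untested is made for them only; others in the source may bear on it.

Compound 3, `CCN1CCN(c2cccc3c2C[C@H](CN(C)[C@H]2CCCc4cccnc42)NC3)CC1`, stands lowest of the three compounds in an ADME assay on microsomes from liver (Homo sapiens) for metabolic stability, read by LC-MS, with a stated time of 10 min (on this read-out lower numbers stand for a less stable compound and higher numbers for a more stable compound), with 0%. Compound 1, `C[C@@H]1CN(c2cccc3c2C[C@H](CN(C)[C@H]2CCCc4cccnc42)NC3)C[C@H](C)N1`, gives 100%, and compound 2, `CN(C[C@H]1Cc2c(cccc2N2C[C@@H]3C[C@H]2CN3)CN1)[C@H]1CCCc2cccnc21`, gives 100%. The two steps onto compound 3 are both large: a number 100 percentage points lower from compound 1 to compound 3 (beyond the scatter) and a number 100 percentage points lower from compound 2 to compound 3 (beyond the scatter), while no change at the digits printed from compound 1 to compound 2 (within the scatter).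

Compound 4 is `C[C@@H]1CN(c2cccc3c2C[C@H](CN(C)[C@H]2CCCc4cccnc42)NC3)C[C@H](C)N1C`. The change from compound 3 is 3,4,5-trimethylpiperazin-1-yl in place of 4-ethylpiperazin-1-yl on an aromatic carbon. The step that bears most directly on it is a number 100 percentage points lower from compound 1 to compound 3 (beyond the scatter), since compound 1 carries 3,5-dimethylpiperazin-1-yl at the same aromatic carbon and the entering 3,4,5-trimethylpiperazin-1-yl shares that substitution pattern, with one added methyl. Compound 4 is therefore expected to move a large step upward, a number 60 percentage points higher from compound 3 to compound 4 (beyond the scatter), though compound 1 alone is not a full guide. Compound 4 is estimated at 60%, within 20% to 100%.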

Compound 4, percent of the compound remaining: 24.6%
Estimate against measurement, compound 4: 35.4 percentage points above; low and high end bracket the measured number.
By their numbers in this assay, from the lowest: compound 3; then compound 4; then compounds 1 and 2 (each within the scatter of the next).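

In this assay, a methyl on the ring amine nitrogen is enough to take most of the number away, a number 75.4 percentage points lower from compound 1 to compound 4 (beyond the scatter), so the two carbon methyls of 3,5-dimethylpiperazin-1-yl do not keep the number high once that nitrogen is substituted. With that nitrogen substituted in both compounds, 3,4,5-trimethylpiperazin-1-yl in place of 4-ethylpiperazin-1-yl recovers only part of the range, a number 24.6 percentage points higher from compound 3 to compound 4 (beyond the scatter). At the same aromatic carbon, the group of compound 4 also falls well short of the two-ring group of compound 2, a number 75.4 percentage points lower from compound 2 to compound 4 (beyond the scatter).

These compounds leave open whether an acetyl group or a 2-hydroxyethyl chain on the ring nitrogen would track the methyl or the free amine. Nothing given here accounts for these steps.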